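Amide cap exchange on the cyclopropanecarboxamide series

A few compounds are considered here, and "the series" means these few. Any claim that something is new, unique, unknown or untested is made for them only; others in the source may bear on it.

Of the compounds shown here, two have been tested in a functional assay on COR-L23 cells (Homo sapiens) for antiproliferative activity, read by CellTiter-Glo, with a stated time of 4 days; a lower number here means a stronger inhibitor, a higher number a weaker inhibitor. Compound 1, `O=C(Nc1ccc(CN2C(=O)c3ccccc3C2=O)cc1)[C@@H]1C[C@H]1c1cccnc1`, carries a phthalimidomethyl group on the shared core, and in this assay compound 1 returns only a limit of the assay, > 10000 nM. Compound 2, `C[C@H](NC(=O)CC(F)(F)F)c1ccc(NC(=O)[C@H]2C[C@@H]2c2cccnc2)cc1`, carries the ((2,2,2-trifluoroethyl)carbonyl)amino group on the same core; in this assay compound 2 gives 18 nM. For the measured compounds named here, compound 2 thus holds the only real number so far, the other entry being a limit, (the limit of > 10000 nM in this assay, at which 1 of the 2 values shown sits), and no pairwise step between measured compounds is available.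

Compound 3, `C[C@H](NC(=O)c1ncccn1)c1ccc(NC(=O)[C@H]2C[C@@H]2c2cccnc2)cc1`, is not yet measured. It differs from compound 2 in one place: pyrimidin-2-yl in place of 2,2,2-trifluoroethyl on a carbonyl carbon. The cap is thus changed from ((2,2,2-trifluoroethyl)carbonyl)amino to ((pyrimidin-2-yl)carbonyl)amino while the rest of compound 2 is kept.

Going by the values given here, since no measured step speaks to such a cap exchange, the step expected from compound 2 to compound 3 in this assay is a 1.7-fold higher number from compound 2 to compound 3 (0.22 log units; within the scatter), a change not clearly beyond the scatter in either direction. For compound 3 the value expected in this assay is 30 nM, within 7 nM to 130 nM.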

Compound 3, half-maximal inhibitory concentration: 17 nM
Beside the measured number, compound 3's estimate is 1.8-fold (0.25 log units) above it; measured number inside the range.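

In this assay, pyrimidin-2-yl in place of 2,2,2-trifluoroethyl on a carbonyl carbon gives a 1.1-fold lower number from compound 2 to compound 3 (0.02 log units; within the scatter), so at this position an aromatic ring with hetero atoms stands in for an open chain with no change that can be told from the scatter. For the compounds shown here, this is the first measured step, as the earlier compounds offered no pair that differs in one place, and it shows that the hydrogen-bond acceptors entering with pyrimidin-2-yl, where 2,2,2-trifluoroethyl has none, go with no step beyond the scatter while the rest of compound 2 is kept. No measurement at hand bears on why the two caps read alike.

One step leaves open how far this tolerance reaches, and a phenyl ring, a morpholine or a carboxylic acid on the same carbonyl carbon would each test it. Compound 1 differs from compound 2 in more than one place and gives a limit of the assay, not a number, and it marks no step at this position: the limit of > 10000 nM in this assay, at which 1 of the 3 values shown sits.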